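A few compounds are considered here, and "the series" means these few. Any claim that something is new, unique, unknown or untested is made for them only; others in the source may bear on it.

Compound 2 `[O-][n+]1nc(NCOCc2ccccc2)[n+]([O-])c2ccccc21` stands at the low end of the two numbers shown in a functional assay on K562 cells (Homo sapiens) for cytotoxicity, read by MTT assay, with a stated time of 72 h (a lower number here means a stronger inhibitor, a higher number a weaker inhibitor), giving 16100 nM, while compound 1 `COc1ccc2c(c1)[n+]([O-])nc(NCOCc1ccccc1)[n+]2[O-]`, which gives 27500 nM, lies within the scatter of it. Within the data shown here, the only measured step, a 1.7-fold lower number from compound 1 to compound 2 (0.23 log units; within the scatter), concerns a different part of the shared core and does not bear on the change at hand. Compound 3 `CCCOCNc1n[n+]([O-])c2ccccc2[n+]1[O-]` differs from compound 2 by ethyl in place of phenyl on a saturated chain carbon bound to an oxygen on a saturated carbon. Among the measured compounds shown here, with no measured step touching this position, no shift beyond the scatter is expected in this assay. Compound 3 is therefore estimated at 16000 nM, between 6000 nM and 45000 nM, an expected step of a 1.0-fold lower number from compound 2 to compound 3 (0.00 log units; within the scatter).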

Compound 3, half-maximal inhibitory concentration: 17600 nM
Compound 3: the middle estimate sits 1.1-fold (0.04 log units) below what was measured; low and high end bracket the measured number.
By their numbers in this assay, from the lowest: compounds 2, 3 and 1 (each within the scatter of the next).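

In this assay, among these compounds, a 1.1-fold higher number from compound 2 to compound 3 (0.04 log units; within the scatter) is the first reading at this position, since the earlier step touched only the shared core. Ethyl in place of phenyl on a saturated chain carbon bound to an oxygen on a saturated carbon, read further out as benzyl to propyl, removes the aromatic ring with no shift beyond the scatter. No available measurement explains this reading. As far as these compounds go, whether a longer chain, an amine or a carboxylic acid at this place would shift the number beyond the scatter remains open. From the compounds shown here alone, whether ethyl behaves the same way on the methoxy-bearing core of compound 1 is also open.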